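The compounds below may be only part of what the source reports. "The series", "measured", "known", "first", "only" and "open" are said of these compounds alone.

In a functional assay (QGY7701 cells, Homo sapiens) for inhibition, read by MTT assay, with a stated time of 48 h (a lower number here means a stronger inhibitor, a higher number a weaker inhibitor), two compounds sharing one core have been measured so far. Compound 1 `COc1ccc2c(=O)c(/C=C/C(=O)Nc3ccccc3)coc2c1` gives 14000 nM, and compound 2 `COc1ccc2c(=O)c(/C=C/C(=O)NCc3cccc(F)c3)coc2c1` gives 28600 nM. That is the higher of the two numbers, which makes compound 2 the weaker inhibitor of this pair.

Compound 3 `COc1ccc2c(=O)c(/C=C/C(=O)NCc3ccc(F)cc3)coc2c1` has not yet been measured. Its difference from compound 2 is this: 4-fluorophenyl in place of 3-fluorophenyl on a saturated chain carbon bound to an amide-type nitrogen. In words, it carries 4-fluorophenyl in place of 3-fluorophenyl on a saturated chain carbon bound to an amide-type nitrogen.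

Among the compounds with values here, no measured step tests this swap directly. Within the data shown here, the only step available is a 2.0-fold higher number from compound 1 to compound 2 (0.31 log units; beyond the scatter), which came with 3-fluorobenzyl in place of phenyl on an amide-type nitrogen. That larger replacement produced only a modest step, so a smaller structural change is not expected to do much more, and compound 2 at 28600 nM remains the best starting point.

The estimated change is a 1.1-fold lower number from compound 2 to compound 3 (0.04 log units; within the scatter), so no step beyond the scatter is expected, in either direction. For compound 3 the estimate is 26000 nM, with an expected range of 13000 nM to 50000 nM.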

Compound 3, half-maximal inhibitory concentration: 7960 nM
Beside the measured number, compound 3's estimate is 3.3-fold (0.51 log units) above it; measured number below the stated range.
By their numbers in this assay, from the lowest: compounds 3 and 1 (each within the scatter of the next); then compound 2.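

In this assay, the two compounds have the same atoms joined differently, yet changing 3-fluorobenzyl to 4-fluorobenzyl gives a 3.6-fold lower number from compound 2 to compound 3 (0.56 log units; beyond the scatter). So this part of the molecule responds to where the fluorine sits on the ring, which compounds 1 and 2 alone could not show, and the step from phenyl to a fluorobenzyl group does not have one fixed outcome: a 1.8-fold lower number from compound 1 to compound 3 (0.25 log units; within the scatter) stays within the scatter, whereas the 3-fluorobenzyl group of compound 2 gave a weaker inhibitor than compound 1. Nothing available explains why the two fluorobenzyl groups differ.

The compounds shown include no plain benzyl group, so the contribution of the fluorine cannot be separated from that of the added chain carbon, and a 4-fluorophenyl group placed directly on the amide nitrogen would test that same question from the other side. They also leave open whether the 4-chlorobenzyl or 4-methoxybenzyl group would match the 4-fluorobenzyl group, or whether this result belongs to fluorine alone.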